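The source may hold more compounds than are shown below. What is called first, only, known or untested is meant among the compounds shown, and "the series" means these compounds.

Measured so far (a functional assay on OCI-Ly3 cells (Homo sapiens) for inhibition, read by CellTiter-Glo, with stated times of 48 h and 96 h; on this read-out higher numbers stand for weaker inhibition of growth and lower numbers for stronger inhibition of growth)
- Compound 1 `COc1ccc(C(=O)N[C@H](C(=O)N2CCC[C@H]2C(=O)N[C@@H](CCCNC(=N)N)C(=O)CF)C(C)C)cc1` gives 1670 nM
- Compound 2 `CC(C)[C@H](NC(=O)C1CCCCC1)C(=O)N1CCC[C@H]1C(=O)N[C@@H](CCCNC(=N)N)C(=O)CF` gives 940 nM

Among the measured compounds shown here, compound 2 stands level with the only other measured compound, the step being (a 1.8-fold lower number from compound 1 to compound 2 (0.25 log units; within the scatter)). Compound 3 `CC(C)[C@H](NC(=O)Nc1ccc(Cl)cc1)C(=O)N1CCC[C@H]1C(=O)N[C@@H](CCCNC(=N)N)C(=O)CF` carries one change from compound 2 ((4-chlorophenyl)amino in place of cyclohexyl on a carbonyl carbon), that is, (4-chlorophenyl)amino in place of cyclohexyl on a carbonyl carbon.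

For the measured compounds named here, one measured step bears on this change. Swapping 4-methoxyphenyl for cyclohexyl on that same carbonyl carbon gave only (a 1.8-fold lower number from compound 1 to compound 2 (0.25 log units; within the scatter)), so the two ring types tried there have not separated in this assay. Going by the values given here, that step is thin support, since no measured compound has the amino link or the chlorine, and their contribution is unknown. The expectation therefore stays close to compound 2 (940 nM), with a wide margin. The expected step, (a 1.1-fold higher number from compound 2 to compound 3 (0.03 log units; within the scatter)), is no larger than the scatter, and no direction is favoured with any confidence. Compound 3 is expected at 1000 nM (estimated range 350 nM to 3000 nM).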

Compound 3, concentration for 50% growth inhibition: 780 nM
The estimate for compound 3 lay 1.3-fold (0.11 log units) above the measured number, within the range that was stated.
By their numbers in this assay, from the lowest: compounds 3, 2 and 1 (each within the scatter of the next, the first and the last beyond it).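

In this assay, the step from cyclohexyl to (4-chlorophenyl)amino on this carbonyl carbon (a 1.2-fold lower number from compound 2 to compound 3 (0.08 log units; within the scatter)) does not separate the two groups, so this position accepts the amino link and the chlorine together without a change beyond the scatter. Set against 4-methoxyphenyl, the same group gives the first step at this position that passes the scatter (a 2.1-fold lower number from compound 1 to compound 3 (0.33 log units; beyond the scatter)), although it is modest and compound 2 stays within the scatter of both compound 1 and compound 3. No measurement at hand accounts for either step.

The amino link and the chlorine enter together, so their separate shares cannot be read from these compounds; phenylamino, 4-methoxyphenylamino and cyclohexylamino on the same carbonyl carbon would divide the step from compound 1 to compound 3 into its parts. Also open, going by these compounds, is whether this position keeps the same flat response with a much smaller group such as methyl, or with a group carrying an amine or a carboxylic acid.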